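Cutting back the chain of compound 1

The compounds below may be only part of what the source reports. "The series", "measured", "known", "first", "only" and "open" are said of these compounds alone.

Measured in an ADME assay on HEK293 cells (Homo sapiens) for inhibition, read by MTT assay, with stated times of 18 h and 4 h; a lower number here means a stronger inhibitor, a higher number a weaker inhibitor:
Compound 1 `CCCCCCCCCCOP(=O)(O)OCCSC(=S)N1CCCCCC1`: 70000 nM
Compound 2 `CCCCCCCCCCOP(=O)(O)OCCSC(=S)N1CCCC1`: > 100000 nM
Compound 3 `CCCCCCCCCCOP(=O)(O)OCCSC(=S)N1CCN(C)CC1`: > 100000 nM

Among the measured compounds shown here, compound 1 holds the only actual number. Compound 2 gives > 100000 nM, which is a limit of the assay and not a number. Compound 3 gives > 100000 nM, which is likewise a limit. Together, compound 2 and compound 3 stand at the limit of > 100000 nM in this assay, at which 2 of the 3 values shown sit.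

Compound 4 `CCCOP(=O)(O)OCCSC(=S)N1CCCCCC1` keeps the core of compound 1 but carries hydrogen in place of heptyl on a saturated chain carbon, three bonds along the chain from an oxygen on an unsaturated carbon.

The measured steps all change the group on the thiocarbonyl carbon. They are an at least 1.4-fold higher number from compound 1 to compound 2 (0.15 log units; that floor lies within the scatter) and an at least 1.4-fold higher number from compound 1 to compound 3 (0.15 log units; that floor lies within the scatter), while the third, a step that the two limits leave unreadable from compound 2 to compound 3, adds nothing. None of them touches the chain, so they bear on this change only indirectly.

Starting from compound 1 at 70000 nM, a modest move to a higher number is expected in this assay. A report of compound 4 as a limit is likely. The estimated step is a 2.1-fold higher number from compound 1 to compound 4 (0.33 log units; beyond the scatter). For compound 4 the expected value is 150000 nM, with an estimated range of 70000 nM to 400000 nM.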

Compound 4, half-maximal inhibitory concentration: 54000 nM
Compound 4: the middle estimate sits 2.8-fold (0.44 log units) above what was measured; the measured number lies below the stated range.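

In this assay, hydrogen in place of heptyl on a saturated chain carbon, three bonds along the chain from an oxygen on an unsaturated carbon, gives a 1.3-fold lower number from compound 1 to compound 4 (0.11 log units; within the scatter). Among the compounds shown here, the earlier steps all changed the group on the thiocarbonyl carbon, so this is the first reading from the chain itself, and it shows that the two chain lengths cannot be told apart in this assay: removing the heptyl part leaves the reading within the usual scatter. Like compound 1, compound 4 returns an actual number, so it does not join the compounds held at the assay's limit: the limit of > 100000 nM in this assay, at which 2 of the 4 values shown sit.

The compounds shown leave open whether a chain of another length, such as a pentyl chain or a chain longer than that of compound 1, would also read the same as these two. They also leave open whether the short chain of compound 4 would give a number with pyrrolidin-1-yl, 4-methylpiperazin-1-yl or a piperidin-1-yl group on the thiocarbonyl carbon in place of azepan-1-yl.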